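Sulfonyl series: fluoro to trifluoromethyl, compound 2 to compound 3

The source may hold more compounds than are shown below. What is called first, only, known or untested is meant among the compounds shown, and "the series" means these compounds.

Compound 1 `O=S(=O)(c1ccccc1)c1nc2ccccc2nc1Nc1ccc(C(F)(F)F)cc1`: in a functional assay on A549 cells (Homo sapiens) for cytotoxicity, read by MTT assay, with a stated time of 72 h (on this read-out higher numbers stand for weaker inhibition and lower numbers for stronger inhibition), compound 1 reaches only the assay limit, > 50000 nM, which is not a number.
Compound 2 `O=S(=O)(c1ccc(Br)cc1)c1nc2ccccc2nc1Nc1ccc(F)cc1`: in this assay compound 2 gives 4360 nM.

For the measured compounds named here, compound 2 holds the only numerical value in this assay; the other entry, that of compound 1, is a limit (the limit of > 50000 nM in this assay, at which 1 of the 2 values shown sits). Going by the values given here, the two differ in more than one place, so their values show only that one compound gives a number and the other does not.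

Compound 3 `O=S(=O)(c1ccc(Br)cc1)c1nc2ccccc2nc1Nc1ccc(C(F)(F)F)cc1` keeps the 4-bromophenylsulfonyl part of compound 2 and changes the other aryl: trifluoromethyl in place of fluoro on an aromatic carbon, para to a large group. Among the compounds with values here, no step between measured compounds covers this exchange. Within the data shown here, the same trifluoromethyl substituent is present in compound 1, whose entry is a limit (the limit of > 50000 nM in this assay, at which 1 of the 2 values shown sits), and that is the only guide available. The expectation is a step from compound 2 to compound 3 of a 4.1-fold higher number from compound 2 to compound 3 (0.62 log units; beyond the scatter) toward weaker inhibition in this assay, with a real chance that compound 3 also returns only a limit. The estimate for compound 3 in this assay is 18000 nM, within 4000 nM to 60000 nM.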

Compound 3, half-maximal inhibitory concentration: > 50000 nM
Compound 3: only a limit was reported; the forecaster's own chance of this, stated with the estimate: 40%; middle value at least 2.7-fold (0.44 log units) away from the limit.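

In this assay, for the compounds shown here, trifluoromethyl in place of fluoro on an aromatic carbon, para to a large group, gives an at least 11-fold higher number from compound 2 to compound 3 (1.05 log units; beyond the scatter), the only readable comparison between compounds that differ in one place. This step is a minimum, as compound 3 returns only a limit, so this one exchange is enough to take the compound from a measured value to the assay limit while the 4-bromophenylsulfonyl part stays unchanged. The other step, bromo in place of hydrogen on an aromatic carbon between the two trifluoromethyl compounds, cannot be read: the limit of > 50000 nM in this assay, at which 2 of the 3 values shown sit.

Going by these compounds, it remains open whether a chloro, a methyl, a methoxy or an amine in place of fluoro would keep a number in this assay, or whether the 4-fluorophenyl compound stands alone in doing so. Also open, on these data alone, are how far compound 3 lies past its limit and what bromo in place of hydrogen on the sulfonyl-bearing aryl does in the 4-fluorophenyl setting, where a value could be compared.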